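A few compounds are considered here, and "the series" means these few. Any claim that something is new, unique, unknown or untested is made for them only; others in the source may bear on it.

Compound 2 `c1ccc(-c2cc(-c3ccccn3)nc(-c3ccccn3)c2)cc1` stands at the low end of the numbers shown in a functional assay on HCT-15 cells (Homo sapiens) for antiproliferative activity; on this read-out lower numbers stand for stronger inhibition of growth and higher numbers for weaker inhibition of growth: compound 2 gives 0.37 ug/mL, the lowest of the two numbers measured. Its nearest neighbour, compound 1 `c1ccc(-c2cc(-c3cccnc3)nc(-c3ccccn3)c2)cc1`, gives 40.9 ug/mL, so that the step of a 110-fold lower number from compound 1 to compound 2 (2.04 log units; beyond the scatter) is large and beyond the scatter. Compound 3 `c1ccc(-c2cc(-c3ccsc3)cc(-c3cccnc3)n2)nc1` gives only a limit of this assay, > 100 ug/mL, and no number. The step of an at least 2.4-fold higher number from compound 1 to compound 3 (0.38 log units; beyond the scatter) is therefore at least modest, and it is the one that bears on the change now in question, since it also exchanges a phenyl for a thiophene. Compound 4 `c1ccc(-c2cc(-c3cccs3)cc(-c3ccccn3)n2)nc1` differs from compound 2 in one place: thiophen-2-yl in place of phenyl on an aromatic carbon. On the strength of that one comparable step, an at least 2.4-fold higher number from compound 1 to compound 3 (0.38 log units; beyond the scatter), a modest rise in the number is expected for compound 4, as the step of a 4.1-fold higher number from compound 2 to compound 4 (0.61 log units; beyond the scatter). Compound 4 is thus estimated at 1.5 ug/mL, within a range from 0.3 ug/mL to 8 ug/mL.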

Compound 4, concentration for 50% growth inhibition: 0.11 ug/mL
The estimate for compound 4 lay 14-fold (1.13 log units) above the measured number, outside the stated range (below it).
By their numbers in this assay, from the lowest: compound 4; then compound 2; then compound 1. At a limit, above all of these: compound 3.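

In this assay, a 3.4-fold lower number from compound 2 to compound 4 (0.53 log units; beyond the scatter) shows that this position, opposite the ring nitrogen, tolerates thiophen-2-yl in place of phenyl, and that with two pyridin-2-yl groups present the exchange lowers the number. The earlier exchange of phenyl for a thiophene ran the other way, an at least 2.4-fold higher number from compound 1 to compound 3 (0.38 log units; beyond the scatter), but it brought in thiophen-3-yl on the core of compound 1, so a phenyl-to-thiophene change has no single direction across these pairs. That earlier step rests on a limit for compound 3, not on a number: the limit of > 100 ug/mL in this assay, at which 1 of the 4 values shown sits.

The compounds shown leave open whether the opposite directions belong to the point of attachment of the thiophene or to the pyridin-2-yl and pyridin-3-yl groups elsewhere in the molecule. From the compounds shown here alone, how an amine, a carboxylic acid or a longer alkyl chain would fare at this position also remains open.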